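Urea-side ring swap on a flat sulfamide series

This account rests on a few compounds, and the source may have more. Where it says the series, first, only, none or still open, it means among the compounds named here.

Compound 3 `COc1ncccc1C(=O)NCCC1CCN(S(=O)(=O)NC(=O)NC[C@H]2C[C@@H]3C=C[C@@H]2C3)CC1` gives 20% in a functional assay on the whole organism (blood) with Rattus norvegicus as the target, with stated times of 24 h and 1 h, at a dose of 5 mg/kg by the intraperitoneal route; on this read-out higher numbers stand for a stronger effect at the one dose given and lower numbers for a weaker effect. Compound 1 `Cc1cccc(C(=O)NCCC2CCN(S(=O)(=O)NC(=O)NC[C@@H]3C[C@@H]4C=C[C@@H]3C4)CC2)n1` gives 20% in this assay, and compound 2 `O=C(NC[C@@H]1C[C@@H]2C=C[C@@H]1C2)NS(=O)(=O)N1CCC(CCNC(=O)c2ccc3ccccc3n2)CC1` gives 21%. Compound 3 thus stands level with compound 1 at the digits reported, and its gap to compound 2 lies within the scatter, so no order can be read among the three. For the measured compounds named here, the only measured step, a number 1 percentage points higher from compound 1 to compound 2 (within the scatter), concerns the aryl group on the carbonyl carbon and was itself within the scatter.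

Compound 4 `COc1ncccc1C(=O)NCCC1CCN(S(=O)(=O)NC(=O)NCC2CCCO2)CC1` differs from compound 3 at another place: a group of 5 heavy atoms (4 carbon, 1 oxygen; one five-membered non-aromatic ring with 1 hetero atom) in place of a group of 7 heavy atoms (7 carbon; 2 five-membered non-aromatic rings of carbon only), on a saturated chain carbon bound to an amide-type nitrogen. Going by the values given here, no measured step touches this position, so nothing among the three numbers bears on it directly; the sole guidance is that all three values sit close together regardless of the aryl group. On that basis compound 4 is estimated at 15%, within 2% to 35%. The expected step of a number 5 percentage points lower from compound 3 to compound 4 (within the scatter) is therefore not one beyond the scatter, with the lower end of the range allowing for a loss that cannot be ruled out.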

Compound 4, a percentage reported as activity, at one dose (the size of the read-out at that dose, not a potency): 16%
The estimate for compound 4 lay 1 percentage points below the measured number; low and high end bracket the measured number.
By their numbers in this assay, from the lowest: compounds 4, 1, 3 and 2 (each within the scatter of the next).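

In this assay, for the compounds shown here, oxolan-2-yl in place of the group of 7 heavy atoms on the saturated chain carbon bound to an amide-type nitrogen gives a number 4 percentage points lower from compound 3 to compound 4 (within the scatter), the only measured step at this position. The change removes 2 five-membered non-aromatic rings of carbon only, 1 double bond outside aromatic rings and 3 defined stereocentres, and adds one hydrogen-bond acceptor, yet the read-out at this one dose does not move beyond the scatter. Nothing available explains or bears on this result.

Still open, from the compounds shown here alone, is whether a primary amine, a carboxylic acid or a longer alkyl chain on this carbon would give a step beyond the scatter. Also open, going by these compounds, is whether oxolan-2-yl gives the same read-out with quinolin-2-yl on the carbonyl carbon.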